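A few compounds are considered here, and "the series" means these few. Any claim that something is new, unique, unknown or untested is made for them only; others in the source may bear on it.

Compound 2 `O=C(Nc1nc(-c2cccc(C(F)(F)F)c2F)cs1)c1cnc(N2CCNC(C(=O)O)C2)c(Cl)c1` shares its core with compound 1 `NC(=O)C1CCN(c2ncc(C(=O)Nc3nc(-c4cccc(C(F)(F)F)c4F)cs3)cc2Cl)CC1`. In a physicochemical assay for solubility (on this read-out higher numbers stand for higher solubility and lower numbers for lower solubility), compound 1 gives < 10 ug/mL, which is a limit of the assay rather than a number. In this assay compound 2 likewise gives < 10 ug/mL, again only a limit. Because both readings fall at the limit of < 10 ug/mL in this assay, at which 2 of the 2 values shown sit, the step that the two limits leave unreadable from compound 1 to compound 2 cannot be sized. Compound 3 `O=C(Nc1nc(-c2cccc(C(F)(F)F)c2F)cs1)c1cnc(N2CCC(c3nn[nH]n3)CC2)c(Cl)c1` differs from compound 2 by 4-(2H-tetrazol-5-yl)piperidin-1-yl in place of 3-carboxypiperazin-1-yl on an aromatic carbon. Going by the values given here, no measured step gives a readable size, so the expected change a step that the limit leaves unreadable from compound 2 to compound 3 rests only on the shared limit. Compound 3 is therefore expected to give 8 ug/mL, within a range from 2 ug/mL to 30 ug/mL.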

Compound 3, solubility: < 10 ug/mL
Compound 3: a limit, no number; the forecaster's own chance of this, stated with the estimate: 65%; the middle value is on the limit's open side.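

In this assay, going by these compounds alone, compound 3 gives < 10 ug/mL which is a limit and not a number, so no step among compound 1, compound 2 and compound 3 can be read: the limit of < 10 ug/mL in this assay, at which 3 of the 3 values shown sit. From the compounds shown here alone, whether these three compounds differ at all in this assay stays open.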